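The source may hold more compounds than are shown below. What is called first, only, known or untested is meant among the compounds shown, and "the series" means these compounds.

Among the three compounds measured so far, compound 3 `O=C([C@H]1C[C@H]1F)N1CC2CC(C1)N2` stands lowest: in an assay on SH-EP1 cells for agonist activity at Neuronal acetylcholine receptor; alpha4/beta2 (Homo sapiens), read by FLIPR and calcium flux (a lower number here means that less compound is needed, a higher number that more compound is needed for the effect), compound 3 gives 1500 nM. Compound 1 `CCC(=O)N1CC2CC(C1)N2` gives 5900 nM, and compound 2 `CC(C)C(=O)N1CC2CC(C1)N2` gives 20000 nM. The steps between them are a 3.9-fold lower number from compound 1 to compound 3 (0.59 log units; beyond the scatter), a 13-fold lower number from compound 2 to compound 3 (1.12 log units; beyond the scatter) and a 3.4-fold higher number from compound 1 to compound 2 (0.53 log units; beyond the scatter), so the group attached to the carbonyl carbon clearly shifts the result.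

Compound 4 `O=C([C@@H]1C[C@H]1F)N1CC2CC(C1)N2` is the next step. Its difference from compound 3 is the two compounds have the same atoms and bonds; at least one stereo element is drawn with a configuration in one of them and without one in the other: 1 of 4 stereo elements differ; a stereocentre at a saturated ring carbon is drawn R in compound 3 and S in compound 4. Going by the values given here, none of the measured steps involves a change of a stereocentre; each of them swaps one group for another on the carbonyl carbon or adds a methyl. They therefore do not bear directly on this change, and they give no indication of direction. Since the atoms and bonds are the same, a step of modest size in either direction is expected, and the estimate for compound 4 is a 1.7-fold higher number from compound 3 to compound 4 (0.22 log units; within the scatter), giving 2500 nM with a range from 600 nM to 10000 nM.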

Compound 4, half-maximal effective concentration: 870 nM
Beside the measured number, compound 4's estimate is 2.9-fold (0.46 log units) above it; measured number inside the range.
By their numbers in this assay, from the lowest: compounds 4 and 3 (each within the scatter of the next); then compound 1; then compound 2.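

In this assay, changing the stereocentre at a saturated ring carbon from R to S gives a 1.7-fold lower number from compound 3 to compound 4 (0.24 log units; within the scatter), so this measurement does not separate the two drawn configurations. Replacing ethyl with 2-fluorocyclopropyl still gives a 6.8-fold lower number from compound 1 to compound 4 (0.83 log units; beyond the scatter), and replacing isopropyl with it gives a 23-fold lower number from compound 2 to compound 4 (1.36 log units; beyond the scatter), so the advantage of 2-fluorocyclopropyl over those two groups does not depend on this one configuration. The comparison between the two forms rests on a single drawn difference: the fact that one of compounds 3 and 4 is drawn with a defined configuration and the other without, at the place where they differ.

From the compounds shown here alone, whether the fluorine itself matters is still open, and a plain cyclopropyl group on the carbonyl carbon would address that. Going by these compounds, it is also open how the three stereo elements shared by compound 3 and compound 4 bear on the result, and how a larger ring such as cyclobutyl would read at this place.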